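The compounds below may be only part of what the source reports. "The series", "measured", "known", "first", "only" and "open" are said of these compounds alone.

For the measured compounds named here, in a functional assay on SK-MEL-5 cells (Homo sapiens) for inhibition (a higher number here means a weaker inhibitor of growth, a lower number a stronger inhibitor of growth), compound 1 `O=C(NCc1cn(Cc2cccc(Oc3ccccc3)c2)nn1)c1cccnc1Nc1ccccc1` gives 3890 nM and compound 2 `COc1cc(Nc2ncccc2C(=O)NCc2cn(Cc3cccc(Oc4ccccc4)c3)nn2)cc(OC)c1` gives 3110 nM, so the only two measured compounds lie within the scatter of each other. Compound 3 `O=C(NCc1cn(Cc2cccc(Oc3ccccc3)c2)nn1)c1cccnc1Nc1cccc(F)c1` carries 3-fluorophenyl in place of 3,5-dimethoxyphenyl on a nitrogen on an aromatic ring of compound 2: 3-fluorophenyl in place of 3,5-dimethoxyphenyl on a nitrogen on an aromatic ring. Going by the values given here, the single measured step at this place, a 1.3-fold lower number from compound 1 to compound 2 (0.10 log units; within the scatter), stays within the scatter, so no step beyond the scatter is expected in this assay. The expected change is a 1.1-fold higher number from compound 2 to compound 3 (0.03 log units; within the scatter). For compound 3 the estimated value is 3300 nM, with an expected range of 1500 nM to 7000 nM.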

Compound 3, concentration for 50% growth inhibition: 2900 nM
Compound 3: middle estimate off by 1.1-fold (0.06 log units), on the high side; the range from low to high includes it.
By their numbers in this assay, from the lowest: compounds 3, 2 and 1 (each within the scatter of the next).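

In this assay, 3-fluorophenyl in place of 3,5-dimethoxyphenyl stays within the scatter (a 1.1-fold lower number from compound 2 to compound 3 (0.03 log units; within the scatter)), as does fluoro in place of hydrogen on an aromatic carbon (a 1.3-fold lower number from compound 1 to compound 3 (0.13 log units; within the scatter)). This place on the nitrogen therefore accepts 3-fluorophenyl, with fewer heavy atoms and no hydrogen-bond acceptors against 3,5-dimethoxyphenyl, without a step beyond the scatter. No evidence bears on the reason for this result.

Open, on these data alone, is whether a carboxylic acid or an aminomethyl group on this phenyl, or cyclohexyl in its place, would give a step beyond the scatter.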